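Three measured compounds and a pyridin-3-yl question

The source may hold more compounds than are shown below. What is called first, only, known or untested is meant among the compounds shown, and "the series" means these compounds.

Compound 1 `COc1cc(C(=O)O)ccc1NC(=O)[C@@H]1N[C@@H](CC(C)(C)C)[C@](CNCc2ccncc2)(c2ccc(Cl)cc2F)[C@H]1c1cccc(Cl)c1F`: 200 nM
Compound 2 `COc1cc(C(=O)O)ccc1NC(=O)[C@@H]1N[C@@H](CC(C)(C)C)[C@](CNCc2ccc(O)cc2)(c2ccc(Cl)cc2F)[C@H]1c1cccc(Cl)c1F`: 600 nM
Compound 3 `COc1cc(C(=O)O)ccc1NC(=O)[C@@H]1N[C@@H](CC(C)(C)C)[C@](C)(c2ccc(Cl)cc2F)[C@H]1c1cccc(Cl)c1F`: 500 nM

In a functional assay on RKO cells (Homo sapiens) for inhibition, read by CCK-8 assay, with a stated time of 4 days (a lower number here means a stronger inhibitor, a higher number a weaker inhibitor), the number for compound 3 sits with the higher pair: the data show a 1.2-fold lower number from compound 2 to compound 3 (0.08 log units; within the scatter), and also a 2.5-fold higher number from compound 1 to compound 3 (0.40 log units; beyond the scatter). Compound 4 `COc1cc(C(=O)O)ccc1NC(=O)[C@@H]1N[C@@H](CC(C)(C)C)[C@](CNCc2cccnc2)(c2ccc(Cl)cc2F)[C@H]1c1cccc(Cl)c1F` is made from compound 3 by ((pyridin-3-yl)methyl)amino in place of hydrogen on a saturated chain carbon bound to a saturated ring carbon, which puts a pyridin-3-yl ring where compound 1 has pyridin-4-yl. The closest guide is that step to compound 1, read in reverse. The aryl group matters, however, as the data show a 3.0-fold higher number from compound 1 to compound 2 (0.48 log units; beyond the scatter). Only a small step toward lower numbers is therefore expected, a 1.7-fold lower number from compound 3 to compound 4 (0.22 log units; within the scatter). Compound 4 is estimated at 300 nM, with an expected range of 130 nM to 650 nM.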

Compound 4, half-maximal inhibitory concentration: 910 nM
The estimate for compound 4 lay 3.0-fold (0.48 log units) below the measured number; the measured number lies above the stated range.
By their numbers in this assay, from the lowest: compound 1; then compounds 3, 2 and 4 (each within the scatter of the next).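

In this assay, the place of the ring nitrogen counts at this position: pyridin-3-yl in place of pyridin-4-yl gives a 4.6-fold higher number from compound 1 to compound 4 (0.66 log units; beyond the scatter). Putting ((pyridin-3-yl)methyl)amino in place of hydrogen gives a 1.8-fold higher number from compound 3 to compound 4 (0.26 log units; within the scatter), and pyridin-3-yl in place of 4-hydroxyphenyl gives a 1.5-fold higher number from compound 2 to compound 4 (0.18 log units; within the scatter), so neither step can be read as a change. Of the four compounds shown, only compound 1 stands apart from all the others. No measurement shown here accounts for this. Still open, going by these compounds, is how a pyridin-2-yl ring, or a longer chain between the amine and the ring, would read at this position.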